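Swapping an Aromatic Ring for a Saturated Ring

The source may report more compounds than this note shows. Statements on the series, on what has been measured and on what is new or still open speak of the compounds shown alone.

Compound 2 `O=C(Nc1ccccc1Cl)N1CCC(c2nc(-c3ccc4ccccc4n3)no2)CC1` and compound 1 `COc1ccccc1NC(=O)N1CCC(c2nc(-c3ccc4ccccc4n3)no2)CC1` share one core and differ only in the group on the amide nitrogen. In a functional assay on Shh Light II cells (Mus musculus) for inhibition, read by a luciferase reporter (on this read-out lower numbers stand for stronger inhibition and higher numbers for weaker inhibition), compound 1 gives 410 nM, and compound 2 gives 510 nM. Compound 2 stands at the higher of the two numbers, but the step of a 1.2-fold higher number from compound 1 to compound 2 (0.09 log units; within the scatter) lies within the scatter, so no real difference between the two can be claimed. Compound 3 `O=C(NC1CCCCC1)N1CCC(c2nc(-c3ccc4ccccc4n3)no2)CC1` has not yet been measured. Its change from compound 2 is cyclohexyl in place of 2-chlorophenyl on an amide-type nitrogen. Within the data shown here, the only measured step exchanges one substituent for another on a ring that stays aromatic; no measured step trades an aromatic ring for a non-aromatic one, so that single step gives little guidance here. The estimate for compound 3 therefore stays near compound 2 with a wide range. In this assay compound 3 is expected at 700 nM, between 200 nM and 2500 nM. The expected step is a 1.4-fold higher number from compound 2 to compound 3 (0.14 log units; within the scatter).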

Compound 3, half-maximal inhibitory concentration: 57 nM
Estimate against measurement, compound 3: 12-fold (1.09 log units) above; measured number outside the range, below it.
By their numbers in this assay, from the lowest: compound 3; then compounds 1 and 2 (each within the scatter of the next).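

Among these compounds, the group on the amide-type nitrogen matters in this assay far more than the earlier compounds suggested: exchanging one substituent on the aromatic ring left the number within the scatter, whereas replacing 2-chlorophenyl with cyclohexyl gives an 8.9-fold lower number from compound 2 to compound 3 (0.95 log units; beyond the scatter). Replacing 2-methoxyphenyl with cyclohexyl gives a 7.2-fold lower number from compound 1 to compound 3 (0.86 log units; beyond the scatter), so both aromatic compounds point the same way, with both steps beyond the scatter. No supporting data bear on why the saturated ring gives the lower number.

The compounds shown leave open whether a ring is needed on this nitrogen at all, or whether a smaller ring such as cyclopentyl or an open chain such as n-hexyl would serve as well. They also leave open how a hydroxyl group or an amine on the cyclohexyl ring would change the number.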